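Trifluoromethyl in place of chloro on the urea aryl ring

The source may hold more compounds than are shown below. What is called first, only, known or untested is meant among the compounds shown, and "the series" means these compounds.

Compound 1 `COc1cc(-c2nn(-c3cccc(NC(=O)Nc4ccc(Cl)c(Cl)c4)c3)cc2-c2ccncc2)ccc1Cl` sits at the assay limit in a functional assay on NCI-H322M cells (Homo sapiens) for inhibition, read by sulforhodamine B assay, with a stated time of 48 h; a lower number here means that less compound is tolerated, a higher number that more compound is tolerated: compound 1 gives > 50000 nM, a limit rather than a number. Compound 2 `O=C(Nc1cccc(-n2cc(-c3ccncc3)c(-c3ccc(Cl)c(O)c3)n2)c1)Nc1ccc(Cl)c(Cl)c1` also gives only a limit, > 32500 nM. Compound 3 `O=C(Nc1cccc(-n2cc(-c3ccncc3)c(-c3ccc(Cl)c(O)c3)n2)c1)Nc1cc(C(F)(F)F)cc(C(F)(F)F)c1` gives 23600 nM. The step that the two limits leave unreadable from compound 1 to compound 2 is left unreadable by the two limits the limit of > 32500 nM in this assay, at which 1 of the 3 values shown sits, and (the limit of > 50000 nM in this assay, at which 1 of the 3 values shown sits).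

Compound 4 `COc1cc(-c2nn(-c3cccc(NC(=O)Nc4ccc(Cl)c(C(F)(F)F)c4)c3)cc2-c2ccncc2)ccc1Cl` differs from compound 1 by trifluoromethyl in place of chloro on an aromatic carbon. Within the data shown here, no measured step touches this position, so nothing sets a direction. The expectation is that compound 4 stays at the limit, with a step of a number no higher from compound 1 to compound 4 (the limit leaves the size open) estimated from compound 1 that is not beyond the scatter. Compound 4 is expected at 50000 nM, within 15000 nM to 120000 nM.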

Compound 4, concentration lethal to 50% of the cells: > 32500 nM
Compound 4: no number, only a limit (the forecaster's own chance of this, stated with the estimate: 65%); the middle value lies beyond the limit too.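

Compound 4 gives only a limit, > 32500 nM, and its step from compound 1, which also stands at a limit, cannot be read. From the compounds shown here alone, whether trifluoromethyl in place of chloro shifts the value in this assay remains open.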